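A few compounds are considered here, and "the series" means these few. Any claim that something is new, unique, unknown or untested is made for them only; others in the source may bear on it.

Measured so far in a functional assay on MCF7 cells (Homo sapiens) for cytotoxicity, read by sulforhodamine B assay, with a stated time of 72 h; on this read-out higher numbers stand for weaker inhibition and lower numbers for stronger inhibition:

Compound 1, `Cc1cc(NS(=O)(=O)c2ccc(NCc3coc4ccccc4c3=O)cc2)no1`: in this assay compound 1 gives 34500 nM.
Compound 2, `O=C1/C(=C/c2coc3ccccc3c2=O)N=C(c2ccc(Cl)cc2)N1c1ccc(S(=O)(=O)Nc2ccccn2)cc1`: in this assay compound 2 reaches only the limit > 100000 nM, not a number.
Compound 3, `O=C1/C(=C/c2coc3ccccc3c2=O)N=C(c2ccccc2)N1c1ccc(S(=O)(=O)Nc2ccccn2)cc1`: in this assay compound 3 likewise reaches only the limit > 100000 nM.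

Within the data shown here, compound 2 therefore stands on no number at all in this assay; the one step measured from it, a step that the two limits leave unreadable from compound 2 to compound 3, cannot be read because of the limit of > 100000 nM in this assay, at which 2 of the 3 values shown sit.

Compound 4, `O=C1/C(=C/c2coc3ccccc3c2=O)N=C(c2ccc(Cl)cc2)N1c1ccc(S(=O)(=O)Nc2nccs2)cc1`, differs from compound 2 by 1,3-thiazol-2-yl in place of pyridin-2-yl on a sulfonamide nitrogen.

Among the measured compounds shown here, no measured step touches the sulfonamide nitrogen substituent, so nothing in the present data bears directly on this change. For the measured compounds named here, the single step from compound 2, to compound 3, is unreadable, and the remaining compound, compound 1, shares neither the core nor the sulfonamide substituent of compound 2, so its value gives no step either. The working expectation is that compound 4 stays where compound 2 stands, with a step of a number no higher from compound 2 to compound 4 (the limit leaves the size open) that is expected to be within the scatter, if it can be read at all.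

Compound 4 is thus estimated at 100000 nM, in the range 30000 nM to 300000 nM, with the chance high that this assay again reports only a limit.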

Compound 4, half-maximal inhibitory concentration: > 100000 nM
Compound 4: only a limit was reported; the forecaster's own chance of this, stated with the estimate: 70%; the middle value sits exactly at the limit.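

In this assay compound 4, like compound 2, reaches only a limit and not a number, so no step can be read from compound 2 to compound 4: the limit of > 100000 nM in this assay, at which 3 of the 4 values shown sit.

The compounds shown leave open whether 1,3-thiazol-2-yl in place of pyridin-2-yl on a sulfonamide nitrogen changes the read-out in any compound that gives a number.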